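Replacing 2-chlorophenyl with 3-methoxyphenyl in compound 3

A few compounds are considered here, and "the series" means these few. Any claim that something is new, unique, unknown or untested is made for them only; others in the source may bear on it.

Values in a functional assay on HL-60 cells (Homo sapiens) for inhibition, read by MTT assay, with a stated time of 72 h (a higher number here means a weaker inhibitor, a lower number a stronger inhibitor), so far:
Compound 1 `Cc1ccc(C)c(N2CCN(C(=O)c3oc(C)nc3-c3ccccc3)CC2)c1` gives 31.3 nM
Compound 2 `Cc1nc(-c2ccccc2)c(C(=O)N2CCN(c3ccccc3Cl)CC2)o1` gives 124 nM

Compound 2 holds the higher of the two numbers, which makes it the weaker inhibitor of the pair. Compound 3 `COc1cccc(N2CCN(C(=O)c3oc(C)nc3-c3ccccc3)CC2)c1` keeps the shared core but has 3-methoxyphenyl in place of 2-chlorophenyl on an amine nitrogen in a ring. For the measured compounds named here, the only measured change at this place is a 4.0-fold higher number from compound 1 to compound 2 (0.60 log units; beyond the scatter) and it was modest but beyond the scatter. Going by the values given here, with only that step as a guide, a modest move toward a lower number is expected in this assay for this change. The estimated change is a 1.9-fold lower number from compound 2 to compound 3 (0.28 log units; within the scatter) as a rough expectation. Compound 3 is expected at 65 nM with an estimated range from 20 nM to 200 nM in this assay.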

Compound 3, half-maximal inhibitory concentration: 34.8 nM
Estimate against measurement, compound 3: 1.9-fold (0.27 log units) above, within the range that was stated.
By their numbers in this assay, from the lowest: compounds 1 and 3 (each within the scatter of the next); then compound 2.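

In this assay, 3-methoxyphenyl in place of 2-chlorophenyl gives a 3.6-fold lower number from compound 2 to compound 3 (0.55 log units; beyond the scatter), so this position responds to more than one kind of change on the phenyl ring. Changing 2,5-dimethylphenyl to 3-methoxyphenyl gives a 1.1-fold higher number from compound 1 to compound 3 (0.05 log units; within the scatter), which shows that two quite different sets of groups on the ring can give values that cannot be told apart. Nothing available here explains these differences.

On these data alone, it remains open what 3-chlorophenyl would give, or whether a ring is needed here at all, as a butyl chain would test.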